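Replacing the aryl group on a weakly active compound

The compounds below may be only part of what the source reports. "The series", "measured", "known", "first", "only" and "open" are said of these compounds alone.

Compound 1 (`COc1cccc([C@@H]2[C@H](Oc3ccccc3)C(=O)N2c2cc(OC)c(OC)c(OC)c2)c1`) and compound 2 (`COc1cc(N2C(=O)[C@@H](Oc3ccccc3)[C@H]2c2cccc(O)c2)cc(OC)c1OC`) share one core. For the measured compounds named here, in a functional assay on MCF7 cells (Homo sapiens) for antiproliferative activity, read by MTT assay, with stated times of 24 h and 72 h (a lower number here means a stronger inhibitor, a higher number a weaker inhibitor), compound 1 gives 171000 nM and compound 2 gives 54000 nM as the lower of the only two numbers so far. Going by the values given here, the one measured step, a 3.2-fold lower number from compound 1 to compound 2 (0.50 log units; beyond the scatter) here, is modest and comes with hydrogen in place of methyl on an oxygen on an aromatic ring.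

Compound 3 (`COc1ccc([C@@H]2[C@H](Oc3ccccc3)C(=O)N2c2cc(OC)c(OC)c(OC)c2)c([N+](=O)[O-])c1O`) makes a larger change on a saturated ring carbon of the four-membered non-aromatic ring (a group of 12 heavy atoms (7 carbon, 1 nitrogen, 4 oxygen; one six-membered aromatic ring of carbon only) in place of a group of 7 heavy atoms (6 carbon, 1 oxygen; one six-membered aromatic ring of carbon only), on a saturated ring carbon). The 3-hydroxyphenyl leaves, and a bigger group with one six-membered aromatic ring of carbon only enters. Among the compounds with values here, no measured step covers a replacement of this size, so the single modest step between compound 1 and compound 2 is only a loose guide. A step of similar modest size toward a lower number is expected, estimated as a 2.7-fold lower number from compound 2 to compound 3 (0.43 log units; beyond the scatter) with wide uncertainty. In this assay the estimate for compound 3 is 20000 nM within an expected range from 1500 nM to 120000 nM for now.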

Compound 3, half-maximal inhibitory concentration: 89000 nM
Compound 3: middle estimate off by 4.5-fold (0.65 log units), on the low side; low and high end bracket the measured number.
By their numbers in this assay, from the lowest: compounds 2, 3 and 1 (each within the scatter of the next, the first and the last beyond it).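

A far larger group on the saturated ring carbon of the four-membered non-aromatic ring, in place of the 3-hydroxyphenyl, gives a 1.6-fold higher number from compound 2 to compound 3 (0.22 log units; within the scatter) in this assay and so does not move the number beyond what repeated measurements would show. Set against the methoxy-bearing aryl group of the first compound in the series, the same large group gives a 1.9-fold lower number from compound 1 to compound 3 (0.28 log units; within the scatter) in this assay and so also stays within that scatter, which means this ring carbon can carry a much bigger aryl group with no clear gain or loss in these numbers. No measurement shown here accounts for this outcome.

The new group brings its nitro, hydroxy and methoxy substituents in together, so the effect of any one of them alone cannot be read from these compounds. The compounds shown also leave open what a small methyl group at this carbon, or an aryl ring carrying an amine or a carboxylic acid, would do to the number in this assay on these cells.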